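A few compounds are considered here, and "the series" means these few. Any claim that something is new, unique, unknown or untested is made for them only; others in the source may bear on it.

Compound 1 `Brc1cccc(Cn2ccc3nc(-c4ccccc4)nc-3c2)c1` gives 85000 nM
Compound 2 `CC(C)N(CCn1ccc2nc(-c3ccccc3)nc-2c1)C(C)C` gives > 100000 nM

In an ADME assay on MDBK cells (Bos taurus) for cytotoxicity (on this read-out lower numbers stand for higher toxicity in this test and higher numbers for lower toxicity in this test), compound 2 reads > 100000 nM and that is a limit, not a number. Its place on the scale is therefore only the limit of > 100000 nM in this assay, at which 1 of the 2 values shown sits, and nothing finer.

Compound 3 `CC(C)=CCn1ccc2nc(-c3ccccc3)nc-2c1` carries 2-methylprop-1-en-1-yl in place of (diisopropylamino)methyl on a saturated chain carbon bound to an aromatic nitrogen is the counted change.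

Going by the values given here, the one measured step that bears on this, an at least 1.1-fold higher number from compound 1 to compound 2 (0.07 log units; that floor lies within the scatter), altered the group at that same place. It is only a floor within the scatter, so it shows no real size. Among the compounds with values here, with compound 1 at 85000 nM as the only true number here, a slight downward shift but nothing beyond the scatter is expected, so the expected step in this assay is an at least 1.2-fold lower number from compound 2 to compound 3 (0.09 log units; that floor lies within the scatter) at most. For compound 3 the expected value is 80000 nM within a range of 35000 nM to 100000 nM as estimated here.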

Compound 3, half-maximal cytotoxic concentration: > 100000 nM
Compound 3: a limit, no number (the forecaster's own chance of this, stated with the estimate: 45%); middle value at least 1.2-fold (0.09 log units) from the limit.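

In this assay compound 3 gives > 100000 nM, which is a limit and not a number. Going by these compounds alone, the step between the two limits cannot be read, so the only readable comparison is an at least 1.1-fold higher number from compound 1 to compound 3 (0.07 log units; that floor lies within the scatter), and it shows no real difference. New here is that 2-methylprop-1-en-1-yl, which holds no nitrogen, reaches the same limit as (diisopropylamino)methyl on a saturated chain carbon bound to an aromatic nitrogen, so this test sees no difference between these two groups and the amine nitrogen is not required to reach that limit: the limit of > 100000 nM in this assay, at which 2 of the 3 values shown sit.

Where compound 2 and compound 3 truly lie relative to each other stays open, since neither has a real number. From the compounds shown here alone, it is also open whether a carboxylic acid or a longer chain at this place would give a true value in this assay.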